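This account rests on a few compounds, and the source may have more. Where it says the series, first, only, none or still open, it means among the compounds named here.

Measured compounds in an ADME assay on Huh-7 cells (Homo sapiens) for cytotoxicity; a lower number here means that less compound is tolerated, a higher number that more compound is tolerated:

Compound 1, `CCOc1cc(NC(=O)CCl)c(OCC)cc1NC(C)=O`: > 50000 nM, a limit of the assay rather than a number.
Compound 2, `O=C(COc1ccccc1Cl)Nc1ccc(Oc2ccc(F)cc2)c(C(F)(F)F)c1`: 14200 nM.
Compound 3, `Cc1ccc(C(=O)Nc2ccc(F)cc2)cc1S(=O)(=O)N1CCOCC1`: 16500 nM.

Two numbers and one limit are in hand. For compound 1 only a limit is known, (the limit of > 50000 nM in this assay, at which 1 of the 3 values shown sits). Of the two numbers, compound 3 and compound 2 sit within the usual scatter of each other, so no order between them can be read from this assay.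

Compound 4, `O=C(Nc1ccc(F)cc1)c1ccc(Cl)c(S(=O)(=O)N2CCOCC2)c1`, has not yet been measured in this assay. It is derived from compound 3 by a single change, (chloro in place of methyl on an aromatic carbon); in short, chloro in place of methyl on an aromatic carbon. Within the data shown here, no measured pair shows this exchange, and nothing in the values so far gives a direction for it. The expectation is therefore that compound 4 lands close to compound 3 in this assay, with a step from compound 3 to compound 4 of a 1.1-fold lower number from compound 3 to compound 4 (0.04 log units; within the scatter), none beyond the scatter. In this assay compound 4 is estimated at 15000 nM, expected between 6000 nM and 45000 nM.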

Compound 4, half-maximal cytotoxic concentration: 15600 nM
Compound 4: the middle estimate sits 1.0-fold (0.02 log units) below what was measured; the measured number falls inside the stated range.
By their numbers in this assay, from the lowest: compounds 2, 4 and 3 (each within the scatter of the next). At a limit, above all of these: compound 1.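

In this assay, among these compounds, the exchange of methyl for chloro, on an aromatic carbon ortho to a group of 9 heavy atoms and para to a large group, gives the first pair that differs in one place: a 1.1-fold lower number from compound 3 to compound 4 (0.02 log units; within the scatter), within the scatter. Among the compounds shown here, at this position, then, replacing one heavy atom with another leaves the half-maximal cytotoxic concentration indistinguishable from that of the methyl compound, a reading that the earlier compounds, with no such pair among them, could not offer. Nothing measured bears on why this exchange behaves as it does.

Open, on these data alone, is whether a different kind of group at this same aromatic carbon, such as an amine, a carboxylic acid or a longer chain, would give a step beyond the scatter in this assay rather than one within it. Also open, as far as these compounds go, is whether chloro in place of methyl would read the same at another position on the shared core, as this single pair speaks for one position only.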